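Adding a butyl chain to a weak amino series

The source may report more compounds than this note shows. Statements on the series, on what has been measured and on what is new or still open speak of the compounds shown alone.

Values in a functional assay on FM3A cells (Mus musculus) for antiproliferative activity, read by cell counting, with a stated time of 2 days (a lower number here means a stronger inhibitor, a higher number a weaker inhibitor), follow.
Compound 1 `COc1cc(C(=O)c2sc(N)nc2N)cc(OC)c1OC` gives 63000 nM
Compound 2 `COc1cc(C(=O)c2sc(N(C)C)nc2N)cc(OC)c1OC` gives 12000 nM
Compound 3 `CCN(CC)c1nc(N)c(C(=O)c2cc(OC)c(OC)c(OC)c2)s1` gives 115000 nM

Compound 3 cannot be separated from compound 1, with a 1.8-fold higher number from compound 1 to compound 3 (0.26 log units; within the scatter), but it stands clearly apart from compound 2, with a 9.6-fold higher number from compound 2 to compound 3 (0.98 log units; beyond the scatter). Compound 4 `CCCCN(C)c1nc(N)c(C(=O)c2cc(OC)c(OC)c(OC)c2)s1` has not yet been measured in this assay. Its difference from compound 3 is butyl(methyl)amino in place of diethylamino on an aromatic carbon, with butyl(methyl)amino in place of diethylamino on an aromatic carbon.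

The closest guides are the other exchanges at this place. One is a 9.6-fold higher number from compound 2 to compound 3 (0.98 log units; beyond the scatter), and another is a 5.3-fold lower number from compound 1 to compound 2 (0.72 log units; beyond the scatter). Going by the values given here, these show that this place can move the number, but they give no trend that extends to compound 4, and no measured compound carries a butyl group. The expected change is therefore none beyond the scatter, an estimated 1.3-fold lower number from compound 3 to compound 4 (0.11 log units; within the scatter). For compound 4 the estimated value is 90000 nM, with an expected range from 25000 nM to 250000 nM.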

Compound 4, half-maximal inhibitory concentration: 47000 nM
Compound 4: the middle estimate sits 1.9-fold (0.28 log units) above what was measured, within the range that was stated.
By their numbers in this assay, from the lowest: compound 2; then compounds 4, 1 and 3 (each within the scatter of the next, the first and the last beyond it).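

In this assay, diethylamino and butyl(methyl)amino turn out not to be interchangeable on this aromatic carbon, although both are open-chain amino groups without a net charge (a 2.4-fold lower number from compound 3 to compound 4 (0.39 log units; beyond the scatter)). Replacing one methyl of dimethylamino with butyl raises the number (a 3.9-fold higher number from compound 2 to compound 4 (0.59 log units; beyond the scatter)), but by less than the exchange of dimethylamino for diethylamino does, so the size of the loss does not simply follow the number of carbons in the group. Butyl(methyl)amino also cannot be separated from plain amino (a 1.3-fold lower number from compound 1 to compound 4 (0.13 log units; within the scatter)), which leaves dimethylamino as the only group shown that lowers the number beyond the scatter relative to amino. Nothing among the data shown explains these differences.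

Still open, from the compounds shown here alone, is how ethyl(methyl)amino or propyl(methyl)amino would compare with dimethylamino and butyl(methyl)amino. Going by these compounds, it is equally open whether a ring amine such as pyrrolidine or morpholine would do better than dimethylamino at this place.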